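Cinnamide ketone series: aryl swap on the ethenyl arm

The source may hold more compounds than are shown below. What is called first, only, known or untested is meant among the compounds shown, and "the series" means these compounds.

compound 1 `COc1ccc(C(=O)c2cc(OC)c(OC)c(OC)c2)cc1NC(=O)/C=C/c1cc(OC)c(OC)c(OC)c1`: 3900 nM
compound 2 `C#CCOc1cccc(/C=C/C(=O)Nc2cc(C(=O)c3cc(OC)c(OC)c(OC)c3)ccc2OC)c1`: 13100 nM

In a functional assay on PC-3 cells (Homo sapiens) for cytotoxicity, read by MTT assay, with a stated time of 72 h (on this read-out higher numbers stand for weaker inhibition and lower numbers for stronger inhibition), compound 2 stands highest of the two numbers measured, the nearest being compound 1, the step being a 3.4-fold higher number from compound 1 to compound 2 (0.53 log units; beyond the scatter). Compound 3 `COc1ccc(C(=O)c2cc(OC)c(OC)c(OC)c2)cc1NC(=O)/C=C/c1ccc(F)cc1` differs from compound 2 by 4-fluorophenyl in place of 3-(propargyloxy)phenyl on a double-bonded chain carbon bound to a double-bonded chain carbon. Among the compounds with values here, no measured step covers this exact change; the only step that bears on changes at this place, a 3.4-fold higher number from compound 1 to compound 2 (0.53 log units; beyond the scatter), was modest. The expected step to compound 3 is therefore a 1.2-fold lower number from compound 2 to compound 3 (0.08 log units; within the scatter), which stays within the scatter. Compound 3 is estimated at 11000 nM, with a range from 3500 nM to 35000 nM.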

Compound 3, half-maximal inhibitory concentration: 3200 nM
For compound 3 the middle estimate is 3.4-fold (0.54 log units) above the measured one, and the stated range ends above it.
By their numbers in this assay, from the lowest: compounds 3 and 1 (each within the scatter of the next); then compound 2.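

In this assay, 4-fluorophenyl in place of 3-(propargyloxy)phenyl gives a clear change (a 4.1-fold lower number from compound 2 to compound 3 (0.61 log units; beyond the scatter)), whereas 4-fluorophenyl in place of 3,4,5-trimethoxyphenyl does not (a 1.2-fold lower number from compound 1 to compound 3 (0.09 log units; within the scatter)). The three methoxy groups are therefore not required for this level of cytotoxicity, and among these three compounds only compound 2 stands apart. No supporting data explain this difference.

From the compounds shown here alone, whether the propargyloxy group itself or its place sets compound 2 apart remains open. An unsubstituted phenyl or 4-aminophenyl on this chain carbon would extend the comparison.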